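This account rests on a few compounds, and the source may have more. Where it says the series, first, only, none or still open, it means among the compounds named here.

For the measured compounds named here, compound 2 `CCCCOc1cccc(C(=O)Nc2cccc(C(=O)O)c2)c1` gives 3150 nM in an assay on isolated protein for agonist activity at Bile acid receptor (Homo sapiens), read by TR-FRET, with a stated time of 3 h, in the absence of a further agent (a lower number here means that less compound is needed, a higher number that more compound is needed for the effect), the highest of the two numbers known here. Compound 1 `Cc1ccc(NC(=O)c2ccc(Oc3ccccc3)cc2)cc1C(=O)O` gives 127 nM in this assay, so compound 1 and compound 2 differ in more than one place and only their two values can be set side by side; the gap between them lies beyond the scatter.

Compound 3 `O=C(O)c1cccc(NC(=O)c2cccc(OCC3CC3)c2)c1` is reached from compound 2 by a single change: cyclopropyl in place of propyl on a saturated chain carbon bound to an oxygen on an aromatic ring. The chain keeps the same count of heavy atoms, and neither a donor nor an acceptor is added or removed, so the compound changes only in the shape of that short chain.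

From compound 2 to compound 3 the step is expected to be small, not beyond the scatter in either direction, as a 1.3-fold lower number from compound 2 to compound 3 (0.10 log units; within the scatter) states. Compound 3 is accordingly estimated at 2500 nM, with a range from 800 nM to 8000 nM.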

Compound 3, half-maximal effective concentration: 1260 nM
Beside the measured number, compound 3's estimate is 2.0-fold (0.30 log units) above it; low and high end bracket the measured number.
By their numbers in this assay, from the lowest: compound 1; then compound 3; then compound 2.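

Replacing butoxy with cyclopropylmethoxy gives a 2.5-fold lower number from compound 2 to compound 3 (0.40 log units; beyond the scatter) in this assay, so the number at this place, on a saturated chain carbon bound to an oxygen on an aromatic ring, depends on the shape of the chain and not only on its count of heavy atoms. For the compounds shown here, the step is modest, but it is the first in this set that can be read as a single change, since compound 1 differs from compound 2 in more than one place. Nothing measured here explains how the three-membered ring shifts the number.

On these data alone, it remains open whether cyclobutyl, a longer chain such as hexyl, or an amine at the end of the chain would lower the number further. It is also unknown whether the same exchange would have a similar effect on the core of compound 1.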